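Series notes: aryl swap on the amine-bound chain carbon

The source may hold more compounds than are shown below. What is called first, only, known or untested is meant among the compounds shown, and "the series" means these compounds.

Compound 1 `c1coc(CN2CCN(CCCc3c[nH]c4ccc(-n5cnnc5)cc34)CC2)c1` gives 18 nM in an assay on CHO cells for displacement of a labelled ligand from 5-hydroxytryptamine receptor 1B (Homo sapiens); a higher number here means a weaker inhibitor, a lower number a stronger inhibitor.
Compound 2 `c1c[nH]c(CN2CCN(CCCc3c[nH]c4ccc(-n5cnnc5)cc34)CC2)n1` gives 36 nM in this assay.

Compound 2 sits at the higher of the two numbers, separated from compound 1 only by a 2.0-fold higher number from compound 1 to compound 2 (0.30 log units; within the scatter), within the scatter. Compound 3 `CC(=O)Nc1ccc(CN2CCN(CCCc3c[nH]c4ccc(-n5cnnc5)cc34)CC2)cc1` differs from compound 2 by 4-acetamidophenyl in place of 1H-imidazol-2-yl on a saturated chain carbon bound to an amine nitrogen in a ring. Among the compounds with values here, the only measured step bearing on this change is a 2.0-fold higher number from compound 1 to compound 2 (0.30 log units; within the scatter), which stayed within the scatter, so one aryl exchange at that position has moved little; the entering group is larger and no measured step covers that. Compound 3 is therefore expected to show a 1.1-fold higher number from compound 2 to compound 3 (0.05 log units; within the scatter), nothing beyond the scatter. The estimate for compound 3 is 40 nM, ranging from 10 nM to 160 nM.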

Compound 3, half-maximal inhibitory concentration: 56 nM
Estimate against measurement, compound 3: 1.4-fold (0.15 log units) below, within the range that was stated.
By their numbers in this assay, from the lowest: compounds 1, 2 and 3 (each within the scatter of the next, the first and the last beyond it).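

In this assay the place on a saturated chain carbon bound to an amine nitrogen in a ring tolerates the larger 4-acetamidophenyl in place of 1H-imidazol-2-yl (a 1.6-fold higher number from compound 2 to compound 3 (0.19 log units; within the scatter)). Within the data shown here, in place of furan-2-yl the same group gives the first step here to pass the scatter, and a modest one (a 3.1-fold higher number from compound 1 to compound 3 (0.49 log units; beyond the scatter)). Nothing available speaks to the origin of either step.

Still open, from the compounds shown here alone, is whether plain phenyl would match 4-acetamidophenyl, and how a carboxylic acid or a primary amine in place of the acetamido group would read.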